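The source may hold more compounds than are shown below. What is called first, only, known or untested is meant among the compounds shown, and "the series" means these compounds.

Series notes on the shared core of compound 3 `CCCSc1nc(N)nc2c1ncn2/C=C1/CC1(CO)CO`. In an ADME assay on BCBL1 cells (Homo sapiens) for cytotoxicity, with a stated time of 7 days (on this read-out lower numbers stand for higher toxicity in this test and higher numbers for lower toxicity in this test), compound 3 gives > 20000 nM, which is a limit of the assay and not a number. Compound 1 `CCCCSc1nc(N)nc2c1ncn2/C=C1/CC1(CO)CO` carries butylsulfanyl on the aromatic carbon in question; in this assay compound 1 gives > 20000 nM, also a limit. Compound 2 `CC(C)CNc1nc(N)nc2c1ncn2/C=C1/CC1(CO)CO` carries isobutylamino there; in this assay compound 2 gives > 20000 nM, again a limit. Hence (the limit of > 20000 nM in this assay, at which 3 of the 3 values shown sit), and compound 3 stands at that limit alongside both other measured compounds, with no ordering among the three readable.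

The step to compound 4 `Nc1nc(OCC(F)(F)F)c2ncn(/C=C3/CC3(CO)CO)c2n1` is 2,2,2-trifluoroethoxy in place of propylsulfanyl on an aromatic carbon. Of the measured steps, a step that the two limits leave unreadable from compound 1 to compound 3 and a step that the two limits leave unreadable from compound 2 to compound 3 lead to compound 3, and a step that the two limits leave unreadable from compound 1 to compound 2 joins its two neighbours; each is unreadable in size, both ends sitting at the limit. Among the compounds with values here, they offer no measurable step to carry over; they show only that exchanges of this kind on the aromatic carbon have not brought the read-out down to a number. On that basis no step beyond the scatter is expected, and a step that the limit leaves unreadable from compound 3 to compound 4 is the expected step. For compound 4 the estimate in this assay is 25000 nM, with a range from 12000 nM to 60000 nM, and a limit rather than a number is the expected report.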

Compound 4, half-maximal cytotoxic concentration: > 20000 nM
Compound 4: no number, only a limit; the forecaster's own chance of this, stated with the estimate: 85%; the middle value lies beyond the limit too.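

In this assay, within the data shown here, compound 4 gives > 20000 nM, a limit and not a number, so no step from compound 1, compound 2 or compound 3 to compound 4 can be read: the limit of > 20000 nM in this assay, at which 4 of the 4 values shown sit. The compounds shown leave open how the four rank against one another, and whether any group on that aromatic carbon gives a numerical read-out.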